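Fluorine on the phenoxy ring of an aryloxyacetic acid agonist

The compounds below may be only part of what the source reports. "The series", "measured", "known", "first", "only" and "open" are said of these compounds alone.

Measured compounds:
Compound 1 `O=C(O)COc1ccc(NC(=O)COc2ccccc2)cc1F` — "not determined" (no result reported).
Compound 2 `CC(Oc1ccccc1)C(=O)Nc1ccc(OCC(=O)O)c(F)c1` — 135 nM.

Two compounds share a core that carries a carboxylic acid on one aromatic ring and an amide linking it to a phenoxy group. In a functional assay on CHO cells for agonist activity at Free fatty acid receptor 1 (Homo sapiens), read by FLIPR (on this read-out lower numbers stand for an effect already at smaller amounts and higher numbers for an effect only at larger amounts of compound), compound 2 gives 135 nM. Within the data shown here, compound 1 was also prepared, but no result was reported for it in this assay, so compound 2 stands alone as the only compound with a number.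

Compound 3 `CC(Oc1ccccc1F)C(=O)Nc1ccc(OCC(=O)O)c(F)c1` has not yet been measured. It differs from compound 2 in a single place: fluoro in place of hydrogen on an aromatic carbon. The phenoxy group becomes a 2-fluorophenoxy group, and everything else stays the same.

Among the measured compounds shown here, there is no measured step between two compounds from which the size of such a change could be read. The change adds only a single fluorine atom, so the expected step from compound 2 to compound 3 is small, a 1.1-fold lower number from compound 2 to compound 3 (0.05 log units; within the scatter), which is not beyond the usual scatter in either direction. Compound 3 is therefore expected to give about 120 nM, estimated to lie between 50 nM and 300 nM.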

Compound 3, half-maximal effective concentration: 136 nM
Compound 3: the middle estimate sits 1.1-fold (0.05 log units) below what was measured; low and high end bracket the measured number.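

In this assay, among these compounds, the first step that can be read for this change is a 1.0-fold higher number from compound 2 to compound 3 (0.00 log units; within the scatter). Fluoro in place of hydrogen on this aromatic carbon, ortho to a large group, turns phenoxy into 2-fluorophenoxy, and the read-out shows no difference that stands out from the scatter. So this position accepts one fluorine atom with agonist activity kept, which the single number for compound 2 could not show on its own. Nothing shown offers a measured explanation for this result.

A single fluorine atom is a small test, so the result does not tell whether a larger group at the same position, such as chloro, methoxy or trifluoromethyl, would also leave the number in place. It also leaves open whether fluoro on the other carbons of this ring, or an amine at any of them, would behave the same way.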